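Notes on the methylpiperidine analogue, compound 3

This account rests on a few compounds, and the source may have more. Where it says the series, first, only, none or still open, it means among the compounds named here.

Compound 1 `COc1ccc(-c2cc(C(=O)Nc3ccc(Oc4ccnc5cc(OCCCN6CCCCC6)c(OC)cc45)c(F)c3)c3ccccc3n2)cc1` is the reference point of this small set. In a functional assay on SMMC-7721 cells (Homo sapiens) for cytotoxicity, read by MTT assay, with a stated time of 72 h (on this read-out lower numbers stand for stronger inhibition and higher numbers for weaker inhibition), compound 1 gives 210 nM, the lowest of the two numbers in hand. Within the data shown here, the only other measured member is compound 2 `COc1cccc(-c2cc(C(=O)Nc3ccc(Oc4ccnc5cc(OCCCN6CCCCC6)c(OC)cc45)c(F)c3)c3ccccc3n2)c1`, which in this assay gives 380 nM. The step of a 1.8-fold higher number from compound 1 to compound 2 (0.26 log units; within the scatter) stays within the scatter, so the two cannot be ranked, and that step concerns the methoxyphenyl group rather than the piperidin-1-yl ring at the other end of the molecule.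

Compound 3 `COc1ccc(-c2cc(C(=O)Nc3ccc(Oc4ccnc5cc(OCCCN6CCC(C)CC6)c(OC)cc45)c(F)c3)c3ccccc3n2)cc1` is the unmeasured analogue. It differs from compound 1 by methyl in place of hydrogen on a saturated ring carbon. Among the measured compounds shown here, no measured step touches the piperidin-1-yl ring, so nothing in hand bears directly on this change; the single measured step, at a distant position, was itself within the scatter. A methyl added on a saturated ring carbon is expected to leave the number close to that of compound 1, with no step beyond the scatter in either direction. Compound 3 is therefore expected to give 250 nM in this assay, with a range of 100 nM to 600 nM. The expected step is a 1.2-fold higher number from compound 1 to compound 3 (0.08 log units; within the scatter).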

Compound 3, half-maximal inhibitory concentration: 450 nM
Compound 3: middle estimate off by 1.8-fold (0.26 log units), on the low side; measured number inside the range.
By their numbers in this assay, from the lowest: compounds 1, 2 and 3 (each within the scatter of the next, the first and the last beyond it).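

In this assay, among these compounds, the change from piperidin-1-yl to 4-methylpiperidin-1-yl gives the first reading at this end of the molecule: a 2.1-fold higher number from compound 1 to compound 3 (0.33 log units; beyond the scatter), a modest step for a single added carbon. Among the compounds shown here, the only earlier step, a 1.8-fold higher number from compound 1 to compound 2 (0.26 log units; within the scatter), concerned the methoxyphenyl group and stayed within the scatter, so the saturated ring carbon three ring bonds from the ring nitrogen is the one place in this small set where a change has moved the number beyond the scatter, though only just. Nothing in hand accounts for this step, and no measurement on the compounds bears on its cause.

The compounds shown leave open whether the higher number belongs to methyl alone or extends to other groups on the same ring carbon, such as ethyl, hydroxyl or a primary amine, and whether replacing the whole ring with morpholin-4-yl would read differently. For the compounds shown here, they also leave open whether the same methyl would produce a similar step on compound 2, which carries the 3-methoxyphenyl group, since only one such pair at this ring is available.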